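From Hydroxy to Methoxy: One Methyl Added

The source may report more compounds than this note shows. Statements on the series, on what has been measured and on what is new or still open speak of the compounds shown alone.

Compound 1 `O=C(N/N=C/c1ccccc1Cl)Nc1ccc(Br)cc1` and compound 2 `COc1cc(/C=N/NC(=O)Nc2ccc(Br)cc2)ccc1O` share a common core and differ only in the groups carried on one aromatic ring. In a functional assay on the whole organism with Mus musculus as the target, in the maximal electroshock model, with a stated time of 0.5 h (on this read-out lower numbers stand for an effect already at smaller amounts and higher numbers for an effect only at larger amounts of compound), compound 1 gives 300 mg/kg, and compound 2 gives 300 mg/kg, level with compound 1 within the scatter. Compound 3 `COc1ccc(/C=N/NC(=O)Nc2ccc(Br)cc2)cc1OC` is compound 2 with methyl in place of hydrogen on an oxygen on an aromatic ring. Among the compounds with values here, no measured pair shows what such a change does here, so the expected step of no change at the digits printed from compound 2 to compound 3 (within the scatter) is none beyond the scatter. Compound 3 is therefore estimated to give 300 mg/kg in this assay, between 100 mg/kg and 600 mg/kg.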

Compound 3, minimum effective dose: 300 mg/kg
Estimate against measurement, compound 3: no gap at the digits printed; measured number inside the range.
By their numbers in this assay, from the lowest: compounds 1, 2 and 3 (each within the scatter of the next).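

In this assay, within the data shown here, methyl in place of hydrogen on an oxygen on an aromatic ring gives no change at the digits printed from compound 2 to compound 3 (within the scatter), the first measured pair for this change. At this place, then, hydroxy can give way to methoxy without the read-out moving beyond the scatter. Nothing measured here explains this result.

From the compounds shown here alone, whether a longer chain on this oxygen, such as propyl, would also leave the number level stays open. So does the outcome of putting an amine or a carboxylic acid at this place.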